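A Benzyl Sulfone Replaces an Aryl Sulfone

The source may hold more compounds than are shown below. What is called first, only, known or untested is meant among the compounds shown, and "the series" means these compounds.

compound 1 `Cc1ccc(/C=C(\C(=O)c2ccc(Br)cc2)S(=O)(=O)Cc2ccc(F)cc2)s1`: 1000 nM
compound 2 `O=C(/C(=C\c1ccc(Br)cc1)S(=O)(=O)c1ccc(Br)cc1)c1ccc(Br)cc1`: 10000 nM
compound 3 `O=C(/C(=C\c1ccc(F)cc1Cl)S(=O)(=O)c1ccc(Br)cc1)c1ccc(Br)cc1`: 50000 nM

In a functional assay on DU-145 cells (Homo sapiens) for inhibition, read by trypan blue exclusion, with a stated time of 96 h (a higher number here means a weaker inhibitor of growth, a lower number a stronger inhibitor of growth), compound 2 stands second highest of the three numbers, between compound 3 and compound 1. Compound 4 `O=C(/C(=C\c1ccc(Br)cc1)S(=O)(=O)Cc1ccc(F)cc1)c1ccc(Br)cc1` differs from compound 2 in one place: 4-fluorobenzyl in place of 4-bromophenyl on a sulfonyl sulfur. Going by the values given here, the only measured step, a 5.0-fold higher number from compound 2 to compound 3 (0.70 log units; beyond the scatter), concerns a different position and does not bear on this change. Compound 1, which also carries the 4-fluorobenzyl on the sulfonyl sulfur, gives a lower number than compound 2, but it differs from compound 2 in two places, so the data lack a clean reading of this change. A modest improvement is expected, a 3.3-fold lower number from compound 2 to compound 4 (0.52 log units; beyond the scatter). Compound 4 is estimated at 3000 nM, between 800 nM and 15000 nM.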

Compound 4, concentration for 50% growth inhibition: 25000 nM
For compound 4 the middle estimate is 8.3-fold (0.92 log units) below the measured one; the measured number lies above the stated range.
By their numbers in this assay, from the lowest: compound 1; then compound 2; then compounds 4 and 3 (each within the scatter of the next).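

In this assay, 4-fluorobenzyl in place of 4-bromophenyl on a sulfonyl sulfur brings no gain, giving a 2.5-fold higher number from compound 2 to compound 4 (0.40 log units; beyond the scatter) for this change. With 4-fluorobenzyl held fixed, 4-bromophenyl in place of 5-methylthiophen-2-yl gives a 25-fold higher number from compound 1 to compound 4 (1.40 log units; beyond the scatter) and is the larger step, so the low number of compound 1 goes with 5-methylthiophen-2-yl and not with 4-fluorobenzyl. Nothing available explains either step.

Still open, from the compounds shown here alone, is how an unsubstituted benzyl or a simple methyl would fare on a sulfonyl sulfur. Also open, going by these compounds, is whether 5-methylthiophen-2-yl keeps its advantage when 4-bromophenyl sits on that sulfur.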